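The compounds below may be only part of what the source reports. "The series", "measured", "known", "first", "only" and "open" are said of these compounds alone.

Compound 1 `Cc1cc2ccccc2nc1-c1cn(CCC(F)(F)C(F)(F)C(F)(F)C(F)(F)C(F)(F)C(F)(F)C(F)(F)C(F)(F)F)nn1` stands at the higher of the two numbers in a functional assay on U-937 cells (Homo sapiens) for cytotoxicity, read by MTT assay, with a stated time of 24 h (a higher number here means a weaker inhibitor, a lower number a stronger inhibitor), giving 56.6 ug/mL; compound 2 `CCCCCCCCCCn1cc(-c2nc3ccccc3cc2CCC)nn1` gives 26.6 ug/mL, and the gap between the two lies beyond the usual scatter. Compound 3 `CCc1cc2ccccc2nc1-c1cn(CCC(F)(F)C(F)(F)C(F)(F)C(F)(F)C(F)(F)C(F)(F)C(F)(F)C(F)(F)F)nn1` is not yet measured; against compound 1 it carries methyl in place of hydrogen on a saturated chain carbon bound to an aromatic carbon. Going by the values given here, no measured pair shows this change, and with only one added carbon the step is expected to stay within the usual scatter, in no clear direction. For compound 3 the estimate in this assay is 50 ug/mL, with a range from 25 ug/mL to 110 ug/mL, which amounts to an expected step of a 1.1-fold lower number from compound 1 to compound 3 (0.05 log units; within the scatter).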

Compound 3, half-maximal inhibitory concentration: 55.9 ug/mL
The estimate for compound 3 lay 1.1-fold (0.05 log units) below the measured number, and the stated range covers the measured number.
By their numbers in this assay, from the lowest: compound 2; then compounds 3 and 1 (each within the scatter of the next).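

In this assay, going by these compounds alone, the change from 3-methylquinolin-2-yl to 3-ethylquinolin-2-yl gives the first single-place step (a 1.0-fold lower number from compound 1 to compound 3 (0.01 log units; within the scatter)). With the rest of compound 1 held fixed, methyl in place of hydrogen on a saturated chain carbon bound to an aromatic carbon therefore leaves the number within the scatter. No measured evidence on a cause bears on this result.

Still open, on these data alone, is whether a longer chain or an amine at this place would give a step beyond the scatter. Also open, as far as these compounds go, is whether the same change reads alike with the chain of compound 2.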